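Swapping the amide substituent of compound 1 toward a carboxylic acid

The source may report more compounds than this note shows. Statements on the series, on what has been measured and on what is new or still open speak of the compounds shown alone.

Measured compounds:
- Compound 1, `CCN(CC)CCNC(=O)c1ccc(C(CC)(CC)c2ccc(OCCC(O)(CC)CC)c(C)c2)n1CC`, gives 3350 nM in a functional assay on PC-3 cells (Homo sapiens) for antiproliferative activity, read by MTT assay, with a stated time of 48 h; a lower number here means a stronger inhibitor, a higher number a weaker inhibitor.
- Compound 2, `CCOC(=O)C(CC(=O)OC)NC(=O)c1ccc(C(CC)(CC)c2ccc(OCCC(O)(CC)CC)c(C)c2)n1CC`, gives 5840 nM in this assay.

Among these two numbers compound 1 has the lowest, and its nearest neighbour is compound 2, separated by a 1.7-fold higher number from compound 1 to compound 2 (0.24 log units; within the scatter), a gap within the scatter. The two therefore cannot be ranked against each other.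

Compound 3, `CCn1c(C(=O)N(C)CC(=O)O)ccc1C(CC)(CC)c1ccc(OCCC(O)(CC)CC)c(C)c1`, has not yet been measured in this assay. It differs from compound 1 in one place: (carboxymethyl)(methyl)amino in place of (2-(diethylamino)ethyl)amino on a carbonyl carbon. Going by the values given here, the only measured step that bears on this change is the one in which a different group replaced the same (2-(diethylamino)ethyl)amino on the amide-type nitrogen, namely a 1.7-fold higher number from compound 1 to compound 2 (0.24 log units; within the scatter). Among the compounds with values here, that exchange left the number within the scatter, so the single relevant precedent points to a small effect at most. On that basis compound 3 is expected to sit close to compound 1, with an estimated step of a 1.3-fold higher number from compound 1 to compound 3 (0.13 log units; within the scatter), no larger than the scatter. The estimate for compound 3 is 4500 nM, within a range from 2000 nM to 10000 nM.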

Compound 3, half-maximal inhibitory concentration: 2250 nM
Compound 3: middle estimate off by 2.0-fold (0.30 log units), on the high side, and the stated range covers the measured number.
By their numbers in this assay, from the lowest: compounds 3, 1 and 2 (each within the scatter of the next, the first and the last beyond it).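

Across the amide substituent, compound 3 gives the first gap beyond the scatter in this assay: a 2.6-fold lower number from compound 2 to compound 3 (0.41 log units; beyond the scatter), a modest step, whereas the earlier pair could not be ranked. Against compound 1 the picture is different, with a 1.5-fold lower number from compound 1 to compound 3 (0.17 log units; within the scatter), so (carboxymethyl)(methyl)amino and (2-(diethylamino)ethyl)amino on this carbonyl carbon cannot be told apart, even though the two groups share little beyond their attachment through nitrogen. This position therefore accepts a chain ending in a carboxylic acid with no measurable loss against compound 1, and the three numbers span only a narrow range, so the substituent changes the result modestly at most; no supporting measurement is available to explain any of these numbers.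

The compounds shown leave open whether the methyl on the amide nitrogen or the carboxymethyl part matters more, a question that a plain (carboxymethyl)amino group or a longer chain carrying the same acid could address. They also leave open whether a ring amine such as morpholine or piperazine at this place would move the number beyond the scatter relative to compound 1.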